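The source may report more compounds than this note shows. Statements on the series, on what has been measured and on what is new or still open speak of the compounds shown alone.

Among the measured compounds shown here, compound 2 `CCCCCCNC(=O)CC1CCc2cc(OC)c(OC)cc21` gives 42.1% in a functional assay on the whole organism (strain Wistar) for inhibition, with Rattus norvegicus as the target, read by paw edema, with stated times of 60 min and 4 h, at a dose of 100 mg/kg by the oral route (a lower number here means less inhibition, a higher number more inhibition at the dose given (going by the name of the read-out)), and so stands at the top of the two numbers measured so far, but only by a gap within the scatter from compound 1 `COc1cc2c(cc1OC)C(CC(=O)N(C)C)CC2`, which gives 35.9%. Compound 3 `COc1cc2c(cc1OC)C(CC(=O)NC1CCCC1)CC2` has not yet been measured; it differs from compound 2 in one place: cyclopentyl in place of hexyl on an amide-type nitrogen. For the measured compounds named here, the only measured step that bears on this change is the one that also swapped the group on the amide-type nitrogen, a number 6.2 percentage points higher from compound 1 to compound 2 (within the scatter), a shift within the scatter. Exchanging one such group for another has therefore not moved the read-out beyond the usual noise so far, and with just two measured compounds no wider pattern can be claimed. The expected step is a number 2.1 percentage points lower from compound 2 to compound 3 (within the scatter), that is, none beyond the scatter. Compound 3 is expected to give about 40%, with a range from 25% to 55%.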

Compound 3, a percentage reported as inhibition, in the whole organism at one dose (the size of the read-out at that dose, not a potency): 45.3%
The estimate for compound 3 lay 5.3 percentage points below the measured number, within the range that was stated.
By their numbers in this assay, from the lowest: compounds 1, 2 and 3 (each within the scatter of the next).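

In this assay, putting a cyclopentyl ring in place of the open hexyl chain on the amide-type nitrogen gives a number 3.2 percentage points higher from compound 2 to compound 3 (within the scatter) and so shows that a ring can replace a chain here with no shift that stands out from the noise. The comparison of cyclopentylamino with dimethylamino on the carbonyl carbon gives a number 9.4 percentage points higher from compound 1 to compound 3 (within the scatter) and so places all three groups at this position within the scatter of one another. Nothing available explains these numbers or links them to any feature of the groups.

Still open, on these data alone, is whether a different kind of group on this nitrogen, such as a phenyl ring, a chain ending in an amine or one ending in a carboxylic acid, would move the read-out beyond the scatter. Readings at one dose also leave open how these compounds compare in potency.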